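A few compounds are considered here, and "the series" means these few. Any claim that something is new, unique, unknown or untested is made for them only; others in the source may bear on it.

Measured so far:
compound 1 `N#CC1=C(N)N(c2ccc(S(N)(=O)=O)cc2)C2=C(C(=O)CCC2)C1c1ccc(Cl)cc1Cl`: 50%
compound 2 `N#CC1=C(NC(=S)Nc2ccccc2)N(c2ccc(S(N)(=O)=O)cc2)C2=C(C(=O)CCC2)C1c1ccc(Cl)cc1Cl`: 50%

In a functional assay on Ehrlich cells (Mus musculus) for cytotoxicity, read by trypan blue exclusion, with a stated time of 2 h, tested at 25 ug/mL (on this read-out higher numbers stand for a stronger effect at the one concentration tested and lower numbers for a weaker effect), compound 1 gives 50% and stands level with compound 2, which gives 50% in this assay. Among the compounds with values here, the one measured step at this amine nitrogen, no change at the digits printed from compound 1 to compound 2 (within the scatter), stayed within the scatter. Compound 3 `N#CC1=C(NC(=O)CCC(=O)O)N(c2ccc(S(N)(=O)=O)cc2)C2=C(C(=O)CCC2)C1c1ccc(Cl)cc1Cl` differs from compound 1 by (2-carboxyethyl)carbonyl in place of hydrogen on an amine nitrogen. Within the data shown here, this again replaces the hydrogen on the same amine nitrogen, and with the single relevant step flat, the step of no change at the digits printed from compound 1 to compound 3 (within the scatter) in this assay is expected to stay within the scatter too. Compound 3 is therefore estimated at 50%, with a range from 35% to 65%.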

Compound 3, a percentage reported as activity, at one concentration (the size of the read-out at that concentration, not a potency): 35%
Estimate against measurement, compound 3: 15 percentage points above; the range from low to high includes it.
By their numbers in this assay, from the lowest: compound 3; then compounds 1 and 2 (each within the scatter of the next).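

In this assay, this amine nitrogen no longer looks indifferent to what replaces its hydrogen: placing (2-carboxyethyl)carbonyl there gives a number 15 percentage points lower from compound 1 to compound 3 (beyond the scatter). Exchanging the group on the same nitrogen gives a number 15 percentage points lower from compound 2 to compound 3 (beyond the scatter), so the substituents at this position are now told apart, which the earlier flat step could not show. No evidence at hand bears on this result.

The compounds shown leave open whether the lower number goes with the carboxylic acid or with the chain that carries it. A methyl ester of the same chain, or a longer chain ending in a carboxylic acid, would separate the two.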